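Fluoromethyl to difluoromethyl: expected half-life gain

The compounds below may be only part of what the source reports. "The series", "measured", "known", "first", "only" and "open" are said of these compounds alone.

In an in vitro ADME assay on microsomes from liver (Simiiformes) (on this read-out higher numbers stand for a longer-lived compound and lower numbers for a shorter-lived compound), compound 1 `Cc1cc(-c2noc(C3CC3)n2)cc(C)c1OCCCc1cc(C2CC2)no1` gives > 2.5 h, which is a limit of the assay and not a number. Compound 2 `CCc1cc(CCCOc2c(C)cc(-c3noc(C(F)(F)F)n3)cc2C)on1` gives > 2.5 h, again a limit of the assay. Among the measured compounds shown here, compound 3 `Cc1cc(CCCOc2c(C)cc(-c3noc(CF)n3)cc2C)on1` gives 0.233 h, the only true number among the three.

Compound 4 `Cc1cc(CCCOc2c(C)cc(-c3noc(C(F)F)n3)cc2C)on1` differs from compound 3 by fluoro in place of hydrogen on a saturated chain carbon bound to an aromatic carbon and a fluorine atom, which takes fluoromethyl to difluoromethyl. For the measured compounds named here, the series holds no measured step that differs in one place, so the expectation is loose. Compound 2 carries trifluoromethyl and differs elsewhere too, and it reads > 2.5 h in this assay, a limit. A lengthening beyond the scatter is expected, with the expected step being a 4.3-fold higher number from compound 3 to compound 4 (0.63 log units; beyond the scatter). For compound 4 the estimated half-life is 1 h, with an expected range of 0.3 h to 3.5 h.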

Compound 4, half-life: 1.42 h
Compound 4: the middle estimate sits 1.4-fold (0.15 log units) below what was measured; the range from low to high includes it.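

Fluoromethyl to difluoromethyl gives the series its first readable step in this assay (a 6.1-fold higher number from compound 3 to compound 4 (0.78 log units; beyond the scatter)). A single fluoro in place of hydrogen on this saturated chain carbon is enough to move the half-life beyond the scatter, and compound 4 is the second compound here with a true number rather than a limit.

Going by these compounds, how plain methyl or hydroxymethyl would read in this place stays open. No step to trifluoromethyl can be read, because compound 2 also differs elsewhere and its value is a limit, not a number: the limit of > 2.5 h in this assay, at which 2 of the 4 values shown sit.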